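The source may report more compounds than this note shows. Statements on the series, on what has been measured and on what is new or still open speak of the compounds shown alone.

Compound 1 `COc1ccc(C(=O)/C=C/c2cc3ccccc3[nH]c2=O)cc1`: in an ADME assay on NCI-H23 cells (Homo sapiens) for cytotoxicity, read by sulforhodamine B assay, with a stated time of 24 h (a higher number here means that more compound is tolerated, a lower number that less compound is tolerated), compound 1 gives > 100000 nM, which is a limit of the assay and not a number.
Compound 2 `O=C(/C=C/c1cc2ccccc2[nH]c1=O)c1ccc(O)cc1`: in this assay compound 2 gives > 100000 nM, again a limit of the assay rather than a number.

Compound 2 therefore stands at the limit of > 100000 nM in this assay, at which 2 of the 2 values shown sit, and nothing shown places it any more precisely than that. Among the compounds with values here, the only measured step, a step that the two limits leave unreadable from compound 1 to compound 2, hydrogen in place of methyl on an oxygen on an aromatic ring, joins two limits and so gives no readable size and no direction.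

Compound 3 `O=C(/C=C/c1cc2ccccc2[nH]c1=O)c1ccc(Cl)cc1` is the next compound, differing from compound 2 by chloro in place of hydroxy on an aromatic carbon. Within the data shown here, the one measured step touches the same ring but a different group, and it is unreadable, so there is no basis for expecting a step of any size in this assay in either direction; the most likely outcome is that compound 3 also lands at the limit. Compound 3 is therefore estimated at 100000 nM, between 30000 nM and 300000 nM, the step of a number no higher from compound 2 to compound 3 (the limit leaves the size open) being an expectation of no change beyond the scatter.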

Compound 3, concentration lethal to 50% of the cells: > 100000 nM
Compound 3 was reported as a limit; the forecaster's own chance of this, stated with the estimate: 70%; the middle value lies on the limit itself.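

Within the data shown here, no step among compound 1, compound 2 and compound 3 can be read, because all three values are limits of the assay and not numbers: the limit of > 100000 nM in this assay, at which 3 of the 3 values shown sit.

The compounds shown leave open how far each one lies past that limit, and whether methoxy, hydroxy or chloro on this ring changes the result in this assay at all.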